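The source may report more compounds than this note shows. Statements on the series, on what has been measured and on what is new or still open speak of the compounds shown alone.

Measured in a functional assay on PC-3 cells (Homo sapiens) for antiproliferative activity, read by MTT assay, with a stated time of 72 h; on this read-out higher numbers stand for weaker inhibition and lower numbers for stronger inhibition:
- Compound 1 `O=C(N/N=C/c1cccc(Br)c1)Nc1ccc(Oc2ccnc3[nH]ccc23)c(F)c1`: 4020 nM
- Compound 2 `O=C(N/N=C/c1cccc(Cl)c1Cl)Nc1ccc(Oc2ccnc3[nH]ccc23)c(F)c1`: "not active" (no number reported)
- Compound 3 `O=C(N/N=C/c1cc(Br)c(O)c(Br)c1)Nc1ccc(Oc2ccnc3[nH]ccc23)c(F)c1`: "not active" (no number reported)

Compound 2 has no single number in this assay. It stands with compound 3 as an entry reported without a value, and only compound 1 gives a figure.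

Next is compound 4 `O=C(N/N=C/c1cccc(Cl)c1Cl)Nc1ccc(Oc2ccnc3[nH]ccc23)cc1`, not yet measured. The structural change is hydrogen in place of fluoro on an aromatic carbon, with the rest of the structure unchanged. Among the measured compounds shown here, no measured pair isolates this change, and with no number for compound 2 no step can be calculated from it. The expectation is therefore no step beyond the scatter, in either direction, so compound 4 should stay close to compound 2 and may also be reported without a number. If a number is obtained, the only anchor is compound 1 at 4020 nM, and a value in that region or somewhat weaker is expected. For compound 4 the estimated value in this assay is 6000 nM, with an expected range from 2000 nM to 20000 nM.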

Compound 4, half-maximal inhibitory concentration: "not active" (no number reported)
Nothing numeric was reported for compound 4, and the estimate cannot be compared.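

Compound 2 and compound 4 are both reported as not active, without a number, in this assay, so no step can be read for hydrogen in place of fluoro. No measured evidence bears on this result. With compound 1 at 4020 nM as the only number, the compounds shown leave open what this change does where a value can be measured.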